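Swapping a Pyrrole for a Methylfuran on a Weak Acrylamide

The source may report more compounds than this note shows. Statements on the series, on what has been measured and on what is new or still open speak of the compounds shown alone.

Of the compounds shown here, three have been tested in a functional assay on HT-29 cells (Homo sapiens) for inhibition, read by MTT assay, with a stated time of 72 h; a lower number here means a stronger inhibitor of growth, a higher number a weaker inhibitor of growth. Compound 1 `N#C/C(=C\c1c[nH]c2ccccc12)C(=O)c1c[nH]c2ccccc12` gives 6000 nM, the lowest value among the three. Sharing an acrylonitrile amide chain with compound 2, compound 3 `N#C/C(=C\c1ccc[nH]1)C(=O)NCc1ccc(Cl)c(Cl)c1` gives 85000 nM. On these data alone, compound 2 `COc1ccc(CNC(=O)/C(C#N)=C/c2ccc[nH]2)cc1` reaches only a limit, > 50000 nM, so its true value is unknown and it cannot be placed relative to the others; this is the limit of > 50000 nM in this assay, at which 1 of the 3 values shown sits.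

Compound 4 `COc1ccc(CNC(=O)/C(C#N)=C/c2ccc(C)o2)cc1` differs from compound 2 in one place: 5-methylfuran-2-yl in place of 1H-pyrrol-2-yl on a double-bonded chain carbon bound to a double-bonded chain carbon, in words 5-methylfuran-2-yl in place of 1H-pyrrol-2-yl on a double-bonded chain carbon bound to a double-bonded chain carbon.

Going by the values given here, no measured pair shows what such a change does here, and the starting point is itself a limit. The expectation is a step of no clear size or direction, a step that the limit leaves unreadable from compound 2 to compound 4, and a value that may again be a limit. Compound 4 is estimated at 60000 nM in this assay, within a range from 20000 nM to 200000 nM.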

Compound 4, concentration for 50% growth inhibition: 92000 nM
Beside the measured number, compound 4's estimate is 1.5-fold (0.19 log units) below it; the range from low to high includes it.
By their numbers in this assay, from the lowest: compound 1; then compounds 3 and 4 (each within the scatter of the next).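

No size or direction can be read for the change from compound 2 to compound 4, because compound 2 gives only a limit in this assay: the limit of > 50000 nM in this assay, at which 1 of the 4 values shown sits.

The compounds shown leave open whether 5-methylfuran-2-yl in place of 1H-pyrrol-2-yl strengthens, weakens or leaves unchanged the growth inhibition.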